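Carboxylic acid to methanesulfonyl carboxamide in compound 3

This account rests on a few compounds, and the source may have more. Where it says the series, first, only, none or still open, it means among the compounds named here.

Measured so far in an assay on isolated protein for agonist activity at Bile acid receptor (Homo sapiens), read by FRET; a higher number here means that more compound is needed for the effect, a lower number that less compound is needed:
compound 1 `CC(C)c1onc(-c2c(Cl)cccc2Cl)c1COc1ccc(N(C)C(=O)c2ccc(C(=O)O)cc2)c(C(F)(F)F)n1` gives 235 nM
compound 2 `CC(C)c1onc(-c2c(Cl)cccc2Cl)c1COc1ccc(N(C)Cc2ccc(CCC(=O)O)cc2)c(C(F)(F)F)n1` gives 17 nM
compound 3 `CC(C)c1onc(-c2c(Cl)cccc2Cl)c1COc1ccc(N(C)Cc2cccc(C(=O)O)c2)c(C(F)(F)F)n1` gives 12 nM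

Compound 3 holds the lowest number of the three: a 20-fold lower number from compound 1 to compound 3 (1.29 log units; beyond the scatter) and a 14-fold lower number from compound 1 to compound 2 (1.14 log units; beyond the scatter) are both large, whereas a 1.4-fold lower number from compound 2 to compound 3 (0.15 log units; within the scatter) stays within the scatter. Compound 4 `CC(C)c1onc(-c2c(Cl)cccc2Cl)c1COc1ccc(N(C)Cc2cccc(C(=O)NS(C)(=O)=O)c2)c(C(F)(F)F)n1` differs from compound 3 by methanesulfonamido in place of hydroxy on a carbonyl carbon. Among the compounds with values here, no measured step touches this end of the molecule: the two large steps concern the group on the nitrogen on the aromatic ring, and the step between compound 2 and compound 3 swaps one acid-bearing aryl group for another with comparable results. A hydrogen-bond donor is kept. For compound 4 the expected step is a 1.3-fold higher number from compound 3 to compound 4 (0.10 log units; within the scatter), no more than the scatter. Compound 4 is estimated at 15 nM, range 5 nM to 60 nM.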

Compound 4, half-maximal effective concentration: 48 nM
Beside the measured number, compound 4's estimate is 3.2-fold (0.51 log units) below it; low and high end bracket the measured number.
By their numbers in this assay, from the lowest: compounds 3 and 2 (each within the scatter of the next); then compound 4; then compound 1.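

Within the data shown here, compound 4 is the first change to the acid end itself, and in this assay methanesulfonamido in place of hydroxy on the carbonyl carbon gives a 4.0-fold higher number from compound 3 to compound 4 (0.60 log units; beyond the scatter), a modest step beyond the scatter. This end of the molecule therefore responds to substitution, and retaining a hydrogen-bond donor there does not keep the number level with that of compound 3. Nothing available accounts for the shift.

From the compounds shown here alone, whether a tetrazole or a primary carboxamide at this position would fare better remains open. Also open, going by these compounds, is whether the same replacement on the propanoic acid chain of compound 2 would produce a similar step.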